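Cyclic peptide series: sulfanyl to 2-hydroxyethyl at the serine-type position

The compounds below may be only part of what the source reports. "The series", "measured", "known", "first", "only" and "open" are said of these compounds alone.

Measured so far in a functional assay on P388 cells (Mus musculus) for cytotoxicity; on this read-out lower numbers stand for stronger inhibition and higher numbers for weaker inhibition:
compound 1 `COc1ccc(C[C@H]2C(=O)N[C@@H](C)C(=O)N(C)[C@H]3Cc4ccc(cc4)Oc4cc(ccc4OC)C[C@@H](C(=O)N[C@H](C)C(=O)N[C@@H](CO)C(=O)N2C)N(C)C3=O)cc1` gives 14.1 nM
compound 2 `COc1ccc(C[C@H]2C(=O)N[C@@H](C)C(=O)N(C)[C@H]3Cc4ccc(cc4)Oc4cc(ccc4OC)C[C@@H](C(=O)N[C@H](C)C(=O)N[C@@H](CS)C(=O)N2C)N(C)C3=O)cc1` gives 363 nM

Compound 2 stands at the highest of the two numbers, the weaker of the pair. For the measured compounds named here, the single step that connects the two, a 26-fold higher number from compound 1 to compound 2 (1.41 log units; beyond the scatter), is large and beyond the scatter.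

Compound 3 `COc1ccc(C[C@H]2C(=O)N[C@@H](C)C(=O)N(C)[C@H]3Cc4ccc(cc4)Oc4cc(ccc4OC)C[C@@H](C(=O)N[C@H](C)C(=O)N[C@@H](CCCO)C(=O)N2C)N(C)C3=O)cc1` is not yet measured. It differs from compound 2 as follows:
2-hydroxyethyl in place of sulfanyl on a saturated chain carbon bound to a saturated ring carbon

Going by the values given here, only the step from compound 1 to compound 2 bears on this change, and it reverses the element: the sulfanyl that gave the weaker number in compound 2 is now replaced by a group that again carries oxygen, yet on a longer chain than the hydroxy of compound 1. Nothing in the data shows what the added chain length does on its own, so the change is read mainly as a return of the hydroxy-bearing group. For compound 3 a step of a 6.1-fold lower number from compound 2 to compound 3 (0.78 log units; beyond the scatter) toward a lower number is expected, because a 26-fold higher number from compound 1 to compound 2 (1.41 log units; beyond the scatter) was large in the other direction. Compound 3 is therefore estimated at 60 nM, within 15 nM to 250 nM, short of compound 1 given the uncertainty about the chain.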

Compound 3, half-maximal inhibitory concentration: 174 nM
Estimate against measurement, compound 3: 2.9-fold (0.46 log units) below, within the range that was stated.
By their numbers in this assay, from the lowest: compound 1; then compound 3; then compound 2.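

Replacing the sulfanyl with 2-hydroxyethyl at this position in this assay gives only a partial return toward compound 1: the change brings a 2.1-fold lower number from compound 2 to compound 3 (0.32 log units; beyond the scatter), and compound 3 still lies well short of the hydroxy compound, with a 12-fold higher number from compound 1 to compound 3 (1.09 log units; beyond the scatter). Within these compounds, then, a hydroxy group at the end of the side chain does not by itself restore the number of compound 1, and chain length at this position matters: the two hydroxy-bearing compounds differ only in that length, and the step between them is large and beyond the scatter. No measurement available here accounts for either step, so the reason for them remains unknown.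

The compounds shown leave open how the number changes with chain length between the hydroxy of compound 1 and the 2-hydroxyethyl of compound 3, and whether a sulfanyl on the same longer chain would follow the hydroxy series. Also open, as far as these compounds go, is whether the oxygen matters on the longer chain at all, which a plain propyl chain would test, and how an amine or a carboxylic acid at this position would read.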